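Fluoro to trifluoromethoxy: compound 2 to compound 4

A few compounds are considered here, and "the series" means these few. Any claim that something is new, unique, unknown or untested is made for them only; others in the source may bear on it.

Measured so far in a functional assay on HCT-15 cells (Homo sapiens) for inhibition; on this read-out lower numbers stand for stronger inhibition and higher numbers for weaker inhibition:
- compound 1 (`Oc1ccccc1-c1cc(-c2ccccc2F)cc(-c2ccccc2O)n1`): > 50000 nM
- compound 2 (`Oc1ccccc1-c1cc(-c2cccc(F)c2)cc(-c2ccccc2O)n1`): > 50000 nM
- compound 3 (`Oc1ccccc1-c1cc(-c2ccc(F)cc2)cc(-c2ccccc2O)n1`): > 50000 nM

Compound 2 stands at > 50000 nM and this is a limit, not a number. For the measured compounds named here, the whole series so far rests on the limit of > 50000 nM in this assay, at which 3 of the 3 values shown sit, and offers no measured potency. Compound 4 (`Oc1ccccc1-c1cc(-c2cccc(OC(F)(F)F)c2)cc(-c2ccccc2O)n1`) carries trifluoromethoxy in place of fluoro on an aromatic carbon, meta to a large group (trifluoromethoxy in place of fluoro on an aromatic carbon). The measured steps that bear on this change only exchange 2-fluorophenyl, 3-fluorophenyl and 4-fluorophenyl: a step that the two limits leave unreadable from compound 1 to compound 2, a step that the two limits leave unreadable from compound 1 to compound 3 and a step that the two limits leave unreadable from compound 2 to compound 3. None of them has a readable size, and none replaces the fluoro itself, so they give no direction for this change. The expectation rests on compound 2 and its limit of > 50000 nM. The expected result in this assay is a number no higher from compound 2 to compound 4 (the limit leaves the size open), with no clear shift. The estimate for compound 4 is 50000 nM, with an expected range from 15000 nM to 100000 nM.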

Compound 4, half-maximal inhibitory concentration: > 50000 nM
Compound 4: only a limit was reported (the forecaster's own chance of this, stated with the estimate: 70%); the middle value lies on the limit itself.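

In this assay compound 4 gives > 50000 nM, which is a limit and not a number. No step can be read between compound 2 and compound 4, as both values are limits. The compounds shown leave open whether any substituent on the shared core gives a measurable inhibitory potency.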